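Thiazol-2-yl on the ring nitrogen of compound 3

The source may hold more compounds than are shown below. What is called first, only, known or untested is meant among the compounds shown, and "the series" means these compounds.

Compound 1 `O=C(NCCCCc1ccccc1)c1cccc(C2SCC(=O)N2c2ccccn2)c1` gives 19.7 nM in a functional assay on HOS-TE85 cells (Homo sapiens) for inhibition, read by CCK-8 assay, with a stated time of 72 h; a lower number here means a stronger inhibitor, a higher number a weaker inhibitor. Compound 2 `C#Cc1cccc(N2C(=O)CSC2c2cccc(C(=O)NCCCCc3ccccc3)c2)c1` gives 149 nM; compound 3 `COc1cc(F)ccc1N1C(=O)CSC1c1cccc(C(=O)NCCCCc2ccccc2)c1` gives 71.1 nM. Compound 3 stands second highest of the three numbers, with a 2.1-fold lower number from compound 2 to compound 3 (0.32 log units; beyond the scatter) and a 3.6-fold higher number from compound 1 to compound 3 (0.56 log units; beyond the scatter). Compound 4 `O=C(NCCCCc1ccccc1)c1cccc(C2SCC(=O)N2c2nccs2)c1` is not yet measured; its change from compound 3 is 1,3-thiazol-2-yl in place of 4-fluoro-2-methoxyphenyl on an amide-type nitrogen in a ring.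

Both measured changes on this nitrogen start from pyridin-2-yl: a 7.6-fold higher number from compound 1 to compound 2 (0.88 log units; beyond the scatter) and a 3.6-fold higher number from compound 1 to compound 3 (0.56 log units; beyond the scatter). Each six-membered carbon-only ring in place of pyridin-2-yl gave a higher number, so the reverse direction, a five-membered aromatic ring with 2 hetero atoms in place of the 4-fluoro-2-methoxyphenyl, is expected to give a lower number, of a size comparable to the step seen for compound 1 and compound 3 a 3.6-fold higher number from compound 1 to compound 3 (0.56 log units; beyond the scatter). For the measured compounds named here, no measured step with 1,3-thiazol-2-yl exists, so the range is kept wide.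

Compound 4 is expected at 30 nM, between 10 nM and 100 nM, an expected step of a 2.4-fold lower number from compound 3 to compound 4 (0.37 log units; beyond the scatter).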

Compound 4, half-maximal inhibitory concentration: > 1000 nM
Compound 4: no number, only a limit (the forecaster's own chance of this, stated with the estimate: 2%); middle value at least 33-fold (1.52 log units) away from the limit.
By their numbers in this assay, from the lowest: compound 1; then compound 3; then compound 2. At a limit, above all of these: compound 4.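

In this assay compound 4 carries only a limit, not a number: the limit of > 1000 nM in this assay, at which 1 of the 4 values shown sits.

The earlier changes on this amide-type nitrogen were modest, whereas 1,3-thiazol-2-yl gives an at least 50-fold higher number from compound 1 to compound 4 (1.70 log units; beyond the scatter), an at least 14-fold higher number from compound 3 to compound 4 (1.14 log units; beyond the scatter) and an at least 6.7-fold higher number from compound 2 to compound 4 (0.82 log units; beyond the scatter), so a hetero atom in the aromatic ring on this nitrogen does not by itself carry the low number of compound 1. Pyridin-2-yl and 1,3-thiazol-2-yl, both aromatic rings with hetero atoms, thus lie further apart here than pyridin-2-yl and either carbon-only ring.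

Going by these compounds, the true size of the gap stays open, since all three steps rest on a limit. Also open, on these data alone, is whether the gap follows the five-membered ring or the ring sulfur; oxazol-2-yl and pyrimidin-2-yl on this nitrogen would bear on that.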